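From amino to methylamino in an antiproliferative test

The source may hold more compounds than are shown below. What is called first, only, known or untested is meant among the compounds shown, and "the series" means these compounds.

In a functional assay on A-375 cells (Homo sapiens) for antiproliferative activity, read by MTT assay, with a stated time of 96 h (on this read-out higher numbers stand for weaker inhibition and lower numbers for stronger inhibition), compound 1 (`COc1ccc(-c2cnc3c(N)nccn23)cc1OC`) gives > 10000 nM, which is a limit of the assay and not a number. Compound 2 (`CCCS(=O)(=O)Nc1cc(F)c(C(=O)c2c[nH]c3ncc(-c4ccc(Cl)cc4)cc23)c(F)c1`), a structurally different compound, gives 139 nM, a measured value. Compound 3 (`CNc1nccn2c(-c3ccc(OC)c(OC)c3)cnc12`) changes compound 1 in one place: methyl in place of hydrogen on a nitrogen on an aromatic ring. Going by the values given here, no measured pair shows this change, so only a small expected step is estimated a step that the limit leaves unreadable from compound 1 to compound 3, with no firm direction. For compound 3 the estimate is 12000 nM, with an expected range of 3000 nM to 40000 nM.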

Compound 3, half-maximal inhibitory concentration: > 10000 nM
Compound 3 gave a limit, no number (the forecaster's own chance of this, stated with the estimate: 60%); the middle value lies beyond the limit too.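

No step can be read from compound 1 to compound 3, because each gives only a limit of the assay: the limit of > 10000 nM in this assay, at which 2 of the 3 values shown sit.

The compounds shown leave open whether methyl in place of hydrogen on that nitrogen changes the antiproliferative activity at all, and in which direction.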